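The source may report more compounds than this note shows. Statements on the series, on what has been measured and on what is new or still open speak of the compounds shown alone.

Values in an assay on isolated protein for displacement of a labelled ligand from metabotropic glutamate receptor 5 (Homo sapiens), with a stated time of 60 min, tested at 1 uM (on this read-out lower numbers stand for less inhibition and higher numbers for more inhibition at the one concentration tested (going by the name of the read-out)), for the compounds measured so far:

Compound 1 `Cc1ccc(S(=O)(=O)c2cnc3cc(Cl)ccc3c2N2CCC(C)CC2)cc1F` gives 85%.
Compound 2 `COc1cccc(S(=O)(=O)c2cnc3cc(Cl)ccc3c2N2CCC(C)CC2)c1` gives 93%.
Compound 3 `COc1cccc(S(=O)(=O)c2cnc3ccc(OC)cc3c2N2CCC(C)CC2)c1` gives 0%.

Compound 2 and compound 1 share one core and differ only in the aryl group on the sulfonyl sulfur: 3-fluoro-4-methylphenyl in place of 3-methoxyphenyl on a sulfonyl sulfur. In this assay the step is a number 8 percentage points lower from compound 2 to compound 1 (within the scatter), so the two numbers lie within the scatter of each other and no order between them can be read. Compound 3 carries the same 3-methoxyphenyl on the sulfonyl sulfur as compound 2 but a different core; the difference between the two cores is not broken down here. In this assay compound 3 gives 0%, the lowest of the three numbers, beyond the scatter from compound 1 and from compound 2.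

Compound 4 `COc1ccc2ncc(S(=O)(=O)c3ccc(C)c(F)c3)c(N3CCC(C)CC3)c2c1` is not yet measured. It differs from compound 3 as follows: 3-fluoro-4-methylphenyl in place of 3-methoxyphenyl on a sulfonyl sulfur. The place is the same word for word as for the pair compound 2 to compound 1, so this is the same change, occurring twice in all among the compounds here.

For the measured compounds named here, the one earlier instance of this change stayed within the scatter, a number 8 percentage points lower from compound 2 to compound 1 (within the scatter). Compound 3 gives 0% in this assay, which leaves little room downward. The step from compound 3 to compound 4 is therefore expected to be small, a number 3 percentage points higher from compound 3 to compound 4 (within the scatter), because a number 8 percentage points lower from compound 2 to compound 1 (within the scatter) on the other core. Compound 4 is expected to give 3% in this assay, with a range from 0% to 15%. This rests on a single earlier step on a different core, so the expectation is held loosely.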

Compound 4, a percentage reported as inhibition, at one concentration (the size of the read-out at that concentration, not a potency): 73%
Estimate against measurement, compound 4: 70 percentage points below, outside the stated range (above it).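

In this assay, 3-fluoro-4-methylphenyl in place of 3-methoxyphenyl on a sulfonyl sulfur gives a large step on the core of compound 3: a number 73 percentage points higher from compound 3 to compound 4 (beyond the scatter). The size of this step does not carry over from one core to the other, so in these two pairs the outcome of the change depends on the core it is made on: the same change on two cores in this assay, a number 8 percentage points lower (within the scatter) from compound 2 to compound 1 and a number 73 percentage points higher (beyond the scatter) from compound 3 to compound 4, 81 percentage points apart, beyond the scatter of two such steps This does not show which feature of the two cores is responsible, and two pairs give no rule for a further core; the read-out is also taken at a single concentration, so neither step can be read as a difference in potency.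

The compounds shown leave open how the two cores compare with other groups on the sulfonyl sulfur, since only 3-methoxyphenyl and 3-fluoro-4-methylphenyl appear there. On these data alone, whether a group such as an amine, a carboxylic acid or a longer chain in that place would also depend on the core remains unknown, as does the effect of changing the core one part at a time with the group on the sulfonyl sulfur held fixed.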